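The compounds below may be only part of what the source reports. "The series", "measured", "known", "first", "only" and "open" are said of these compounds alone.

In a functional assay on cells for antagonist activity at C-X-C chemokine receptor type 4 (Homo sapiens), read by fluorescence and calcium flux, with stated times of 25 min and 90 s (on this read-out lower numbers stand for stronger inhibition and higher numbers for weaker inhibition), compound 1 `c1ccc2c(c1)CN[C@@H](CN(CCCCNC1CCOCC1)[C@H]1CCCc3cccnc31)C2` gives 29.4 nM, the lowest of the two numbers recorded so far; its nearest neighbour, compound 2 `CC1(C)CCC(NCCCCN(C[C@H]2Cc3ccccc3CN2)[C@H]2CCCc3cccnc32)CC1`, gives 77.6 nM, and the step of a 2.6-fold higher number from compound 1 to compound 2 (0.42 log units; beyond the scatter) accompanies 4,4-dimethylcyclohexyl in place of oxan-4-yl on an amine nitrogen. Compound 3 `C(=C/CN(C[C@H]1Cc2ccccc2CN1)[C@H]1CCCc2cccnc21)\CNCc1cccnc1` has not yet been measured; it differs from compound 1 by a group of 11 heavy atoms (9 carbon, 2 nitrogen; one six-membered aromatic ring with 1 hetero atom) in place of a group of 10 heavy atoms (8 carbon, 1 nitrogen, 1 oxygen; one six-membered non-aromatic ring with 1 hetero atom), on a saturated chain carbon bound to an amine nitrogen. Going by the values given here, only the step from compound 1 to compound 2 bears on this change, and it replaces just oxan-4-yl, whereas compound 3 replaces the whole 3-((oxan-4-yl)amino)propyl group, so it guides only weakly. A modest weakening is expected, a 2.0-fold higher number from compound 1 to compound 3 (0.31 log units; beyond the scatter). Compound 3 is therefore estimated at 60 nM, between 20 nM and 180 nM.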

Compound 3, half-maximal inhibitory concentration: 92.8 nM
For compound 3 the middle estimate is 1.5-fold (0.19 log units) below the measured one; the measured number falls inside the stated range.
By their numbers in this assay, from the lowest: compound 1; then compounds 2 and 3 (each within the scatter of the next).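

In this assay, exchanging the whole 3-((oxan-4-yl)amino)propyl group gives a 3.2-fold higher number from compound 1 to compound 3 (0.50 log units; beyond the scatter), so a change at this place that reaches beyond oxan-4-yl still produces only a modest step. The leaving and entering groups have equal hydrogen-bond donor and acceptor counts, so those counts do not track this step. Nothing available explains the step. As far as these compounds go, the double bond and the six-membered aromatic ring enter together, so their separate contributions remain open. From the compounds shown here alone, how a longer chain or a terminal carboxylic acid would read out at this place also remains open.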